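The source may hold more compounds than are shown below. What is called first, only, known or untested is meant among the compounds shown, and "the series" means these compounds.

Compound 1, `COc1ccc(OCC2=NCCO2)cc1`: 33.2%
Compound 2, `Brc1ccccc1OCC1=NCCO1`: 29.1%

In a functional assay on the whole organism for inhibition, with Rattus norvegicus as the target, read by paw edema, with a stated time of 30 min, at a dose of 40 mg/kg by the oral route (a higher number here means a stronger effect of the compound at the dose given, a lower number a weaker effect), compound 1 gives 33.2%. Its nearest neighbour, compound 2, gives 29.1%, a number within the usual scatter of it, so the two stand together rather than apart. Compound 3, `O=[N+]([O-])c1ccc(OCC2=NCCO2)cc1`, is not yet measured. It differs from compound 1 by nitro in place of methoxy on an aromatic carbon. For the measured compounds named here, no step between measured compounds is available to guide the size of this change, and the two measured values do not separate. The expected step from compound 1 to compound 3 is a number 3.2 percentage points lower from compound 1 to compound 3 (within the scatter), none beyond the scatter. Compound 3 is expected to give 30%, in the range 15% to 45%.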

Compound 3, a percentage reported as inhibition, in the whole organism at one dose (the size of the read-out at that dose, not a potency): 30.4%
Estimate against measurement, compound 3: 0.4 percentage points below; low and high end bracket the measured number.
By their numbers in this assay, from the lowest: compounds 2, 3 and 1 (each within the scatter of the next).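

Nitro in place of methoxy on the aromatic carbon para to a group of 7 heavy atoms gives the first step read at this position, a number 2.8 percentage points lower from compound 1 to compound 3 (within the scatter), in this assay. The two groups differ in their counts of heavy atoms and hydrogen-bond acceptors, yet this read-out at one dose does not tell them apart. Nothing measured on these compounds bears on this result.

From the compounds shown here alone, whether an amine or a carboxylic acid at this position would move the read-out beyond the scatter stays open. So does whether the two groups would also stand together at other doses.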